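A few compounds are considered here, and "the series" means these few. Any claim that something is new, unique, unknown or untested is made for them only; others in the source may bear on it.

Three members of a small family of cytotoxic compounds have been measured. Compound 1 `ClCc1ccccc1Cn1cnc2c(Cl)nc(Cl)nc21` gives 3630 nM in a functional assay on OVCAR-4 cells (Homo sapiens) for cytotoxicity, read by sulforhodamine B assay, with a stated time of 48 h; on this read-out higher numbers stand for weaker inhibition of growth and lower numbers for stronger inhibition of growth. Compound 2 `ClCc1cccc(Cn2cnc3c(Cl)ncnc32)c1` gives 5750 nM in this assay, and compound 3 `ClCc1ccc(Cn2cnc3nc(Cl)nc(Cl)c32)cc1` gives 4160 nM in this assay. On these figures compound 2 carries the largest of the three numbers, yet its gaps to compound 3 and to compound 1 both fall inside the usual scatter of repeated measurements, so the three compounds cannot be told apart on this read-out.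

The next compound to be considered is compound 4 `ClCc1cccc(Cn2cnc3c(Cl)nc(Cl)nc32)c1`. Compared with compound 2 the only change is chloro in place of hydrogen on an aromatic carbon. Compounds 1 and 3 each already carry two chloro groups on the fused core, and their numbers sit close to that of compound 2, so no large shift is expected here. The estimated step of a 1.4-fold lower number from compound 2 to compound 4 (0.14 log units; within the scatter) is expected to stay within the scatter. Compound 4 is therefore expected to give about 4200 nM in this assay, with a likely range from 1500 nM to 12000 nM.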

Compound 4, concentration for total growth inhibition: 20000 nM
For compound 4 the middle estimate is 4.8-fold (0.68 log units) below the measured one, outside the stated range (above it).
By their numbers in this assay, from the lowest: compounds 1, 3 and 2 (each within the scatter of the next); then compound 4.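

In this assay, chloro in place of hydrogen on the aromatic carbon between two ring nitrogen atoms gives a 3.5-fold higher number from compound 2 to compound 4 (0.54 log units; beyond the scatter), which on this read-out means weaker inhibition of growth. For the compounds shown here, this is the first change that can be read on its own, and it shows that this carbon of the shared core is not indifferent to what it carries: a single added chlorine atom moves the number beyond the scatter. Nothing measured here accounts for the shift.

With only hydrogen and chloro shown on this carbon, it remains open how an amine or a methoxy group there would compare. On these data alone, it also remains open whether the same change would give a step of similar size with the chloromethyl group elsewhere on the benzene ring.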